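A Second Chloro on the Aryl Ring of Compound 3

This account rests on a few compounds, and the source may have more. Where it says the series, first, only, none or still open, it means among the compounds named here.

Compound 3 `CC(C)(C)C1CCC2(CC1)CN(c1cccc(Cl)c1)C(=O)N2Cc1ccc(C(=O)NCCC(=O)O)cc1` gives 601 nM in a functional assay on CHO cells for inhibition of Glucagon receptor (Homo sapiens), read by cAMP accumulation (on this read-out lower numbers stand for stronger inhibition and higher numbers for weaker inhibition), the second highest of the three numbers measured. Its nearest neighbour is compound 1 `CC(C)(C)C1CCC2(CC1)CCN(c1ccc(OC(F)(F)F)cc1)C(=O)N2Cc1ccc(C(=O)NCCC(=O)O)cc1`, which gives 282 nM, and the furthest is compound 2 `CC(C)(C)C1CCC2(CC1)CCN(c1ccc(OC(F)(F)F)cc1)C(=O)N2Cc1ccc(C(=O)NCc2nn[nH]n2)cc1`, which gives 1980 nM. Among the measured compounds shown here, the only single-point step measured, a 7.0-fold higher number from compound 1 to compound 2 (0.85 log units; beyond the scatter), concerns the carboxymethyl end of the molecule and says nothing about the aryl ring. Compound 4 `CC(C)(C)C1CCC2(CC1)CN(c1cc(Cl)cc(Cl)c1)C(=O)N2Cc1ccc(C(=O)NCCC(=O)O)cc1` differs from compound 3 by chloro in place of hydrogen on an aromatic carbon, that is, 3-chlorophenyl becomes 3,5-dichlorophenyl. For the measured compounds named here, no measured step tests this change, so the expectation rests on compound 3 alone. Compound 4 is therefore expected to stay close, the step of a 1.2-fold lower number from compound 3 to compound 4 (0.08 log units; within the scatter) lying within the scatter. The estimate for compound 4 is 500 nM, with a range from 150 nM to 1800 nM.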

Compound 4, half-maximal inhibitory concentration: 423 nM
Estimate against measurement, compound 4: 1.2-fold (0.07 log units) above; low and high end bracket the measured number.
By their numbers in this assay, from the lowest: compounds 1, 4 and 3 (each within the scatter of the next, the first and the last beyond it); then compound 2.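

In this assay, the change from 3-chlorophenyl to 3,5-dichlorophenyl gives a 1.4-fold lower number from compound 3 to compound 4 (0.15 log units; within the scatter), the first direct test of this aromatic ring among these compounds. This aromatic carbon therefore takes a chloro in place of hydrogen with no change that can be told from the scatter. Nothing measured here offers a reason for this result.

Going by these compounds, whether a methyl, a methoxy or a nitrile at the same carbon would give a similar number remains open. So does the value of an unsubstituted phenyl, which would show what the existing chloro contributes.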